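Methoxy for methylbenzyl on the piperidine ring

A few compounds are considered here, and "the series" means these few. Any claim that something is new, unique, unknown or untested is made for them only; others in the source may bear on it.

compound 1 `CC(C(=O)NCc1ccc(C(F)(F)F)nc1NCc1ccccc1)c1ccc(NS(C)(=O)=O)c(F)c1`: 203 nM
compound 2 `CC(C(=O)NCc1ccc(C(F)(F)F)nc1N1CCC(C)(C)CC1)c1ccc(NS(C)(=O)=O)c(F)c1`: 8 nM
compound 3 `Cc1ccc(CC2CCN(c3nc(C(F)(F)F)ccc3CNC(=O)C(C)c3ccc(NS(C)(=O)=O)c(F)c3)CC2)cc1`: 17 nM

In a functional assay on CHO-K1 cells for antagonist activity at transient receptor potential cation channel subfamily V member 1 (Homo sapiens), read by FLIPR (a higher number here means a weaker inhibitor, a lower number a stronger inhibitor), compound 3 gives 17 nM, the second highest of the three numbers; compound 2 gives 8 nM and compound 1 gives 203 nM. Compound 4 `COC1CCN(c2nc(C(F)(F)F)ccc2CNC(=O)C(C)c2ccc(NS(C)(=O)=O)c(F)c2)CC1` differs from compound 3 by methoxy in place of 4-methylbenzyl on a saturated ring carbon. Going by the values given here, the only measured step, a 25-fold lower number from compound 1 to compound 2 (1.40 log units; beyond the scatter), concerns the group on the aromatic carbon, not a substituent on the saturated ring, so it bears only loosely on this change. Compounds 2 and 3 both carry a saturated ring at that position and give numbers that are close to each other. A small step downward or none beyond the scatter is therefore expected, a 1.2-fold lower number from compound 3 to compound 4 (0.08 log units; within the scatter). Compound 4 is estimated at 14 nM, with a range of 5 nM to 45 nM.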

Compound 4, half-maximal inhibitory concentration: 280 nM
Compound 4: middle estimate off by 20-fold (1.30 log units), on the low side; measured number outside the range, above it.
By their numbers in this assay, from the lowest: compound 2; then compound 3; then compounds 1 and 4 (each within the scatter of the next).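

In this assay, the substituent on the saturated ring carbon matters far more than compound 2 and compound 3 suggested: methoxy in place of 4-methylbenzyl gives a 16-fold higher number from compound 3 to compound 4 (1.22 log units; beyond the scatter), and 4-methoxypiperidin-1-yl in place of 4,4-dimethylpiperidin-1-yl gives a 35-fold higher number from compound 2 to compound 4 (1.54 log units; beyond the scatter). A saturated ring on the aromatic carbon does not by itself secure a low number, since 4-methoxypiperidin-1-yl in place of benzylamino gives a 1.4-fold higher number from compound 1 to compound 4 (0.14 log units; within the scatter), within the scatter. No available measurement accounts for the rise.

Going by these compounds, whether the rise follows the oxygen itself or the absence of a larger carbon group remains open. An ethyl or a benzyloxy group on the same carbon would help separate the two.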